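This account rests on a few compounds, and the source may have more. Where it says the series, first, only, none or still open, it means among the compounds named here.

In an ADME assay on HEK293 cells (Homo sapiens) for cytotoxicity, with a stated time of 72 h (a higher number here means that more compound is needed for the effect, a lower number that less compound is needed), compound 1 (`C=C[C@@](C)(/C=C/c1ccc(OS(=O)(=O)C(F)(F)F)cc1)CCC=C(C)C`) gives > 36600 nM, which is a limit of the assay and not a number. Compound 2 (`C=C[C@@](C)(/C=C/c1ccc(Nc2ccccc2)cc1)CCC=C(C)C`) gives > 36600 nM, which is also a limit. Compound 2 therefore has no readable number, and the whole record for the two compounds is the limit of > 36600 nM in this assay, at which 2 of the 2 values shown sit. Compound 3 (`C=C[C@@](C)(/C=C/c1ccc(Nc2cccc(OC(F)(F)F)c2)cc1)CCC=C(C)C`) departs from compound 2 by one change, trifluoromethoxy in place of hydrogen on an aromatic carbon. Among the measured compounds shown here, the only measured step, a step that the two limits leave unreadable from compound 1 to compound 2, has no readable size, so it offers no magnitude to carry over. No step beyond the scatter is therefore expected in this assay, in either direction. The expected step is a number no higher from compound 2 to compound 3 (the limit leaves the size open). The estimate for compound 3 is 36600 nM, with an expected range from 12000 nM to 50000 nM, and a report of only a limit is the likeliest outcome.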

Compound 3, half-maximal effective concentration: > 36600 nM
Compound 3 was reported as a limit; the forecaster's own chance of this, stated with the estimate: 70%; the middle value lies on the limit itself.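

The step from compound 2 to compound 3 in this assay cannot be read, as both results are limits of the assay and not numbers. The compounds shown leave open what number any of them would give, and whether either change shifts it, with the record standing at a single value: the limit of > 36600 nM in this assay, at which 3 of the 3 values shown sit.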